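The source may report more compounds than this note shows. Statements on the series, on what has been measured and on what is new or still open speak of the compounds shown alone.

Of the compounds shown here, three have been tested in a functional assay on SW-620 cells (Homo sapiens) for antiproliferative activity, read by sulforhodamine B assay, with a stated time of 72 h (a lower number here means a stronger inhibitor, a higher number a weaker inhibitor), so far. Compound 1 `COc1cc(/C=C/COC(C)=O)ccc1OC(C)=O` gives 360 nM. Compound 2 `CC[C@H](C)C(=O)Oc1ccc(/C=C/COC(C)=O)cc1OC` gives 990 nM. Compound 3 `CCC(=O)OC/C=C/c1ccc(OC(=O)CC)c(OC)c1` gives 47400 nM. Among these three numbers, compound 2 stands second highest: the nearest to it is compound 1, which lies lower, and the furthest is compound 3, which lies far higher.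

The next compound, compound 4 `CCCC(=O)Oc1ccc(/C=C/COC(C)=O)cc1OC`, differs from compound 2 in one place: hydrogen in place of methyl on a saturated chain carbon bound to a carbonyl carbon and a saturated chain carbon. Within the data shown here, the only measured step that touches this part of the molecule is a 2.8-fold higher number from compound 1 to compound 2 (0.44 log units; beyond the scatter), where sec-butyl replaced methyl on a carbonyl carbon and the number rose modestly. Compound 4 carries propyl at that carbonyl, which sits between methyl and sec-butyl in length, so the change from compound 2 is expected to be small, if anything a slightly lower number than compound 2, and possibly within the scatter.

Compound 4 is therefore estimated at 700 nM, with a likely range from 300 nM to 1600 nM, which corresponds to an expected step of a 1.4-fold lower number from compound 2 to compound 4 (0.15 log units; within the scatter) in this assay.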

Compound 4, half-maximal inhibitory concentration: 7590 nM
Compound 4: the middle estimate sits 11-fold (1.04 log units) below what was measured; measured number outside the range, above it.
By their numbers in this assay, from the lowest: compound 1; then compound 2; then compound 4; then compound 3.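

In this assay, removing a single methyl, so that sec-butyl becomes propyl, gives a 7.7-fold higher number from compound 2 to compound 4 (0.88 log units; beyond the scatter), so this small change at the carbonyl matters more than the earlier swap of methyl for sec-butyl suggested. The comparison with the acetate-bearing compound gives a 21-fold higher number from compound 1 to compound 4 (1.32 log units; beyond the scatter), so compound 4 has the highest number of the three compounds that differ only at this carbonyl. The number therefore does not follow chain size in a simple way: propyl, the unbranched group, gives a higher number than the larger sec-butyl.

No measurement shown here accounts for this jump. As far as these compounds go, it remains open whether isopropyl or a longer straight chain such as pentyl at this carbonyl would give a number nearer to that of compound 2 or compound 4.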